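Prenyloxy flavanone series: aryl swap on the saturated ring

A few compounds are considered here, and "the series" means these few. Any claim that something is new, unique, unknown or untested is made for them only; others in the source may bear on it.

Measured so far:
compound 1, `CC(C)=CCOc1ccc2c(c1)OC(c1cccc(Cl)c1)CC2=O`, 6300 nM;
compound 2, `COc1ccc(C2CC(=O)c3ccc(OCC=C(C)C)cc3O2)cc1`, 10200 nM;
compound 3, `CC(C)=CCOc1cc(O)c2c(c1)OC(c1cccc(Cl)c1)CC2=O`, 6060 nM.

All three numbers come from a functional assay; a lower number here means a stronger inhibitor, a higher number a weaker inhibitor. Compound 3 gives the lowest of the three numbers, but one of the two steps that separate it from the others is a 1.0-fold lower number from compound 1 to compound 3 (0.02 log units; within the scatter), and its gap to compound 2 is also within the scatter, so no ordering among the three can be claimed.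

Compound 4, `CC(C)=CCOc1cc(O)c2c(c1)OC(c1ccc(O)cc1)CC2=O`, has not yet been measured. It differs from compound 3 in one place: 4-hydroxyphenyl in place of 3-chlorophenyl on a saturated ring carbon.

Among the compounds with values here, the step that bears on this change is the one from compound 1 to compound 2, where 4-methoxyphenyl replaced 3-chlorophenyl on the same saturated ring carbon; that step was a 1.6-fold higher number from compound 1 to compound 2 (0.21 log units; within the scatter). The hydroxy added on the aromatic carbon in compound 3 gave a 1.0-fold lower number from compound 1 to compound 3 (0.02 log units; within the scatter). Within the data shown here, neither step left the scatter, and no measured pair shows a 4-hydroxyphenyl at this position.

The expectation is therefore a step of about a 1.3-fold higher number from compound 3 to compound 4 (0.12 log units; within the scatter), in the direction of a somewhat higher number but not clearly beyond the scatter. Compound 4 is estimated at 8000 nM, with a range from 3500 nM to 18000 nM.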

Compound 4, half-maximal inhibitory concentration: 5340 nM
Beside the measured number, compound 4's estimate is 1.5-fold (0.18 log units) above it, and the stated range covers the measured number.
By their numbers in this assay, from the lowest: compounds 4, 3, 1 and 2 (each within the scatter of the next).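

In this assay, within the data shown here, the change to 4-hydroxyphenyl in place of 3-chlorophenyl, on the saturated ring carbon next to the ring oxygen, gives a 1.1-fold lower number from compound 3 to compound 4 (0.05 log units; within the scatter) and is the only measured pair with this group at this position. The entering group has a hydrogen-bond donor and acceptor that the leaving group lacks, yet the step stays within the scatter, as does the 4-methoxyphenyl swap in a 1.6-fold higher number from compound 1 to compound 2 (0.21 log units; within the scatter) on the same carbon. No measurement on hand accounts for this result.

No step shown here leaves the scatter, so it is still unknown what kind of group at this carbon would change the number clearly. Open too, going by these compounds, is whether an amine or a carboxylic acid on the aryl group, or a longer chain in place of the prenyloxy group, would do so.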